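Growing a methyl to an isopropyl on the piperidine ring

The source may report more compounds than this note shows. Statements on the series, on what has been measured and on what is new or still open speak of the compounds shown alone.

Three compounds share a sulfonamide core built on two linked six-membered nitrogen rings, and they have been tested in a functional assay on HT-29 cells (Homo sapiens) for antiproliferative activity, read by CellTiter-Glo, with a stated time of 72 h; on this read-out higher numbers stand for weaker inhibition and lower numbers for stronger inhibition. Compound 1 `Cc1cc(C)c(S(=O)(=O)N2CCC(N3CCC(C)CC3)CC2)c(C)c1` gives 0.9 nM in this assay. Compound 2 `CCc1cc(Br)ccc1S(=O)(=O)N1CCC(N2CCC(C)CC2)CC1` gives 0.5 nM, a number that sits within the scatter of the value for compound 1, so the two cannot be told apart. Compound 3 `CC1CCN(C2CCN(S(=O)(=O)c3ccc(Br)cc3OC(F)(F)F)CC2)CC1` gives 4 nM, and here compound 1 stands beyond the scatter on the stronger side. Within the data shown here, the only single-point step among the measured compounds is an 8.0-fold higher number from compound 2 to compound 3 (0.90 log units; beyond the scatter), a change on the aromatic ring rather than on the saturated ring.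

Compound 4 `Cc1cc(C)c(S(=O)(=O)N2CCC(N3CCC(C(C)C)CC3)CC2)c(C)c1` differs from compound 1 by isopropyl in place of methyl on a saturated ring carbon. Among the measured compounds shown here, no measured step touches the saturated ring, so nothing in the data speaks directly to this change; the one step seen concerns a different place of the molecule. The expectation is therefore a modest move at most, with no strong reason to favour either direction. Compound 4 is expected to give 1.5 nM in this assay, within a range from 0.4 nM to 6 nM. This expectation amounts to a 1.7-fold higher number from compound 1 to compound 4 (0.22 log units; within the scatter), a step estimated to stay within the usual scatter.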

Compound 4, half-maximal inhibitory concentration: 0.2 nM
The estimate for compound 4 lay 7.5-fold (0.88 log units) above the measured number; the measured number lies below the stated range.
By their numbers in this assay, from the lowest: compound 4; then compounds 2 and 1 (each within the scatter of the next); then compound 3.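

In this assay, among these compounds, isopropyl in place of methyl on a saturated ring carbon gives a 4.5-fold lower number from compound 1 to compound 4 (0.65 log units; beyond the scatter), a step beyond the scatter and the first measured change at this position. Among the compounds shown here, it shows that this part of the molecule is not indifferent to what it carries, and that going from one heavy atom to three here lowers the number rather than raising it, a move in the opposite direction to the one earlier step on the aromatic ring, an 8.0-fold higher number from compound 2 to compound 3 (0.90 log units; beyond the scatter). No measurement at hand explains why the larger group goes with the lower number.

Going by these compounds, with only methyl and isopropyl seen at this position, it remains open whether tert-butyl, a longer chain such as butyl, or a group carrying an amine would lower the number further or reverse the trend. Also open is whether the same change would have a similar effect on the aromatic rings of compound 2 and compound 3, where only the methyl form is shown.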